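Bromophenyl to Nitrophenyl: A Step Without a Readable Guide

The compounds below may be only part of what the source reports. "The series", "measured", "known", "first", "only" and "open" are said of these compounds alone.

Measured compounds:
compound 1, `COc1ccc(/C=C/C(=O)c2ccc(OC)c3c2OC(C)(C)C=C3)c(F)c1`, > 10000 nM
compound 2, `COc1ccc(C(=O)/C=C/c2ccc(Br)cc2)c2c1C=CC(C)(C)O2`, > 10000 nM

The two measured compounds share one core and differ in the aryl ring on a double-bonded chain carbon bound to a double-bonded chain carbon. In a functional assay on HT-29 cells (Homo sapiens) for antiproliferative activity, read by MTT assay, with a stated time of 24 h (a lower number here means a stronger inhibitor, a higher number a weaker inhibitor), compound 1 gives > 10000 nM, which is a limit of the assay and not a number. In this assay compound 2 gives > 10000 nM, again a limit. Within the data shown here, the one measured step, a step that the two limits leave unreadable from compound 1 to compound 2, therefore has no readable size, and all that is known of compound 2 is that it sits at the limit of > 10000 nM in this assay, at which 2 of the 2 values shown sit.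

Compound 3, `COc1ccc(C(=O)/C=C/c2cccc([N+](=O)[O-])c2)c2c1C=CC(C)(C)O2`, continues from compound 2 by the change (3-nitrophenyl in place of 4-bromophenyl on a double-bonded chain carbon bound to a double-bonded chain carbon). Among the measured compounds shown here, no measured step bears on this change with a readable size; the only comparison available, compound 1 against compound 2, is unreadable because both stand at the limit of > 10000 nM in this assay, at which 2 of the 2 values shown sit. With both measured compounds at the limit, the expected step that the limit leaves unreadable from compound 2 to compound 3 is small and without a known direction. The estimated value for compound 3 in this assay is 20000 nM, with a range from 4000 nM to 100000 nM, and a further limit is the most likely outcome.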

Compound 3, half-maximal inhibitory concentration: 4260 nM
Estimate against measurement, compound 3: 4.7-fold (0.67 log units) above, and the stated range covers the measured number.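

In this assay, the aryl ring on a double-bonded chain carbon bound to a double-bonded chain carbon now proves to be a place where a single change can bring a readable number, and compound 3 is the only compound shown that stands clear of the limit: the limit of > 10000 nM in this assay, at which 2 of the 3 values shown sit. Replacing 4-bromophenyl with 3-nitrophenyl gives an at least 2.3-fold lower number from compound 2 to compound 3 (0.37 log units; beyond the scatter), and replacing 2-fluoro-4-methoxyphenyl with 3-nitrophenyl gives an at least 2.3-fold lower number from compound 1 to compound 3 (0.37 log units; beyond the scatter), so the outcome at this place depends on which aryl group it carries. Each of these steps starts from a limit, so each gives only the smallest size the step can have, and its full size cannot be read.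

The swap from 4-bromophenyl to 3-nitrophenyl alters both the group on the ring and where it sits, and the compounds shown cannot separate these two parts of the change. From the compounds shown here alone, whether the gain belongs to the nitro group itself also stays open, and an amine or a carboxylic acid on the same aryl ring would help to test this in this assay.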